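Inverting One Stereocentre of a Mirror-Image Pair

The source may hold more compounds than are shown below. What is called first, only, known or untested is meant among the compounds shown, and "the series" means these compounds.

In a functional assay on the whole organism for activation, with Mus musculus as the target (on this read-out higher numbers stand for an effect only at larger amounts of compound and lower numbers for an effect already at smaller amounts), compound 1 (`CCCCCCCCc1ccc2c(c1)CC[C@H]([C@](C)(N)CO)C2`) gives > 5 mg/kg as a limit of the assay. Compound 2 (`CCCCCCCCc1ccc2c(c1)CC[C@@H]([C@@](C)(N)CO)C2`), its mirror image, gives 0.8 mg/kg as the only actual number shown. Among the compounds with values here, only the step of an at least 6.2-fold lower number from compound 1 to compound 2 (0.79 log units; beyond the scatter) bears on what follows, and it inverts both stereocentres at once, so the share of each remains unknown. Compound 3 (`CCCCCCCCc1ccc2c(c1)CC[C@H]([C@@](C)(N)CO)C2`) differs from compound 2 in one place: the two compounds have the same atoms and bonds and differ only in configuration as drawn: 1 of 2 stereo elements differ; a stereocentre at a saturated ring carbon is drawn R in compound 2 and S in compound 3 at a saturated ring carbon. Compound 3 carries over only part of the inversion in an at least 6.2-fold lower number from compound 1 to compound 2 (0.79 log units; beyond the scatter), so a moderately higher number is expected. The estimated change is a 2.5-fold higher number from compound 2 to compound 3 (0.40 log units; beyond the scatter) in this assay, towards larger doses. For compound 3 the expected dose is 2 mg/kg, with 0.6 mg/kg to 7 mg/kg as its estimated range.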

Compound 3, dose for half-maximal effect: 0.1 mg/kg
Compound 3: the middle estimate sits 20-fold (1.30 log units) above what was measured; the whole stated range lies above it.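

Inverting only the saturated ring carbon gives an 8.0-fold lower number from compound 2 to compound 3 (0.90 log units; beyond the scatter) in this assay, so this stereocentre alone has a clear effect on the dose, which the mirror-image pair could not separate. With that ring carbon drawn S, inverting only the saturated chain carbon gives an at least 50-fold lower number from compound 1 to compound 3 (1.69 log units; beyond the scatter), leaving compound 3 with the lowest number of the three. For compound 1, > 5 mg/kg is a limit of the assay.

As far as these compounds go, the mirror image of compound 3 remains open, so the effect of inverting the ring carbon with the chain carbon drawn S is unknown. From the compounds shown here alone, it is also open whether this preference would persist with a phosphate ester or a longer chain.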